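The source may report more compounds than this note shows. Statements on the series, on what has been measured and on what is new or still open speak of the compounds shown alone.

Compounds measured in a functional assay on Vero cells (Chlorocebus sabaeus) for inhibition; on this read-out lower numbers stand for stronger inhibition and higher numbers for weaker inhibition:
Compound 1 `OC[C@H]1O[C@H](n2cnc3c(O)ncnc32)CS1` gives > 100000 nM, a limit of the assay.
Compound 2 `Nc1nc(O)c2ncn([C@@H]3CS[C@@H](CO)O3)c2n1` gives 63600 nM.
Compound 3 `O=C1NC(O)C=CN1[C@@H]1CS[C@@H](CO)O1` gives > 100000 nM, a limit of the assay.

Compound 1 stands at the limit of > 100000 nM in this assay, at which 2 of the 3 values shown sit, so it has no number, only a limit. For the measured compounds named here, the single measured step, an at least 1.5-fold lower number from compound 1 to compound 2 (0.19 log units; that floor lies within the scatter), concerns amino in place of hydrogen on an aromatic carbon and is a different change from the one leading to compound 4 `OC[C@H]1O[C@H](n2cnc3c(Cl)ncnc32)CS1`: chloro in place of hydroxy on an aromatic carbon. Going by the values given here, no measured step covers chloro in place of hydroxy, so nothing here points to a step beyond the scatter in this assay in either direction. Compound 4 is therefore expected to give 100000 nM, with a range from 30000 nM to 300000 nM. The expected step is a number no higher from compound 1 to compound 4 (the limit leaves the size open).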

Compound 4, half-maximal inhibitory concentration: 86100 nM
The estimate for compound 4 lay 1.2-fold (0.06 log units) above the measured number; low and high end bracket the measured number.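

Chloro in place of hydroxy on an aromatic carbon, a change no earlier step covered, gives an at least 1.1-fold lower number from compound 1 to compound 4 (0.06 log units; that floor lies within the scatter) in this assay. This position thus accepts chloro, which counts no hydrogen-bond donor, with compound 4 at 86100 nM, yet nothing here shows a change beyond the scatter. The full size of the step stays unknown, since one end of it is only a limit: the limit of > 100000 nM in this assay, at which 2 of the 4 values shown sit.

The compounds shown leave open whether an amine, a methoxy group or a thiol on this same carbon would move the number beyond the scatter. They also leave open whether chloro in place of hydroxy would give a similar step on the core of compound 2.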